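The compounds below may be only part of what the source reports. "The series", "measured", "known", "first", "only" and "open" are said of these compounds alone.

Compound 1 `COc1cc(-c2cc(C(=O)/C=C/c3ccc(Cl)cc3)nc3cc(-c4ccccc4)nn23)cc(OC)c1OC` gives 19500 nM in a functional assay on DU-145 cells (Homo sapiens) for antiproliferative activity, read by MTT assay, with a stated time of 24 h; a lower number here means a stronger inhibitor, a higher number a weaker inhibitor.
Compound 2 `COc1cc(-c2cc(/C=C/C(=O)c3ccc(C)cc3)nc3cc(-c4ccccc4)nn23)cc(OC)c1OC` gives 27100 nM.
Compound 3 `COc1ccc(C(=O)/C=C/c2cc(-c3cc(OC)c(OC)c(OC)c3)n3nc(-c4ccccc4)cc3n2)cc1OC` gives 29900 nM.

Compound 3 has the highest number of the three, although its gaps to compound 2 and to compound 1 both lie within the scatter. Compound 4 `COc1cc(-c2cc(/C=C/C(=O)c3ccc(Cl)cc3)nc3cc(-c4ccccc4)nn23)cc(OC)c1OC` differs from compound 3 by 4-chlorophenyl in place of 3,4-dimethoxyphenyl on a carbonyl carbon. The step that bears directly on this exchange is a 1.1-fold higher number from compound 2 to compound 3 (0.04 log units; within the scatter), where a different aryl group on a carbonyl carbon left the number essentially unchanged; a 1.4-fold higher number from compound 1 to compound 2 (0.14 log units; within the scatter) was also within the scatter, though it alters more than the aryl group. No step beyond the scatter has been seen, so in this assay compound 4 is expected to show a 1.2-fold lower number from compound 3 to compound 4 (0.08 log units; within the scatter), no change beyond the scatter. The estimate for compound 4 is 25000 nM, ranging from 12000 nM to 52000 nM.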

Compound 4, half-maximal inhibitory concentration: 29300 nM
Compound 4: the middle estimate sits 1.2-fold (0.07 log units) below what was measured; the measured number falls inside the stated range.
By their numbers in this assay, from the lowest: compounds 1, 2, 4 and 3 (each within the scatter of the next).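

In this assay, 4-chlorophenyl in place of 3,4-dimethoxyphenyl on the carbonyl carbon (a 1.0-fold lower number from compound 3 to compound 4 (0.01 log units; within the scatter)) and chloro in place of methyl on an aromatic carbon (a 1.1-fold higher number from compound 2 to compound 4 (0.03 log units; within the scatter)) both stay within the scatter, so these three aryl groups on the carbonyl carbon read alike. With the 4-chlorophenyl group held constant, the chain change alone (a 1.5-fold higher number from compound 1 to compound 4 (0.18 log units; within the scatter)) also stays within the scatter, whereas the earlier step from compound 1 to compound 2 altered the aryl group as well. No measurement at hand gives a cause for these flat readings.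

As far as these compounds go, it remains open whether an amine or a carboxylic acid on the aryl ring, or a longer chain in place of ethenyl, would move the number beyond the scatter.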